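Carbamoyl in Place of Methyl on a Squalene Monooxygenase Inhibitor

The source may report more compounds than this note shows. Statements on the series, on what has been measured and on what is new or still open speak of the compounds shown alone.

Compound 1, `CCN(C/C=C/C#CC(C)(C)C)Cc1cccc(OC[Si](C)(C)c2ccc(C)cc2)c1`: 120 nM in a functional assay on liver (Sus scrofa) for inhibition of squalene monooxygenase (Homo sapiens), using microsomes; a lower number here means a stronger inhibitor, a higher number a weaker inhibitor
Compound 2, `CCN(C/C=C/C#CC(C)(C)C)Cc1cccc(OC[Si](C)(C)c2ccc(OC)cc2)c1`: 870 nM
Compound 3, `CCN(C/C=C/C#CC(C)(C)C)Cc1cccc(OC[Si](C)(C)c2ccc(O)cc2)c1`: 8000 nM

Compound 1 gives the lowest number of the three. Both measured steps away from it weaken inhibition: a 7.3-fold higher number from compound 1 to compound 2 (0.86 log units; beyond the scatter) and a 67-fold higher number from compound 1 to compound 3 (1.82 log units; beyond the scatter), and between the two larger compounds a 9.2-fold higher number from compound 2 to compound 3 (0.96 log units; beyond the scatter). Compound 4, `CCN(C/C=C/C#CC(C)(C)C)Cc1cccc(OC[Si](C)(C)c2ccc(C(N)=O)cc2)c1`, carries the change (carbamoyl in place of methyl on an aromatic carbon). Both steps from compound 1 bear on it, since each swapped the methyl for an oxygen-bearing group and each raised the number, the hydroxy step far more than the methoxy step. The carbamoyl, like the hydroxy, brings one hydrogen-bond donor and one acceptor, so a large weakening is expected, about a 42-fold higher number from compound 1 to compound 4 (1.62 log units; beyond the scatter). Compound 4 is therefore estimated at 5000 nM, with a range from 1500 nM to 20000 nM.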

Compound 4, half-maximal inhibitory concentration: 5000 nM
Estimate against measurement, compound 4: no gap at the digits printed; measured number inside the range.
By their numbers in this assay, from the lowest: compound 1; then compound 2; then compounds 4 and 3 (each within the scatter of the next).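

In this assay carbamoyl at this position gives a 42-fold higher number from compound 1 to compound 4 (1.62 log units; beyond the scatter) and so weakens inhibition about as far as hydroxy does, with a 1.6-fold lower number from compound 3 to compound 4 (0.20 log units; within the scatter) between them, while a 5.7-fold higher number from compound 2 to compound 4 (0.76 log units; beyond the scatter) sets it apart from methoxy. The two groups carrying a hydrogen-bond donor thus share the weak end of this short series, whereas methyl, with none, gives the lowest number.

As far as these compounds go, whether a nitrile or a carboxylic acid here would fall in the same place stays open. Nothing measured here explains these losses.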